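The compounds below may be only part of what the source reports. "The series", "measured", "known", "first", "only" and "open" are said of these compounds alone.

Compound 3 `COc1cc(/C=N/NC(=O)Nc2ccc(Oc3ccnc(-c4nncn4CCN(C)C)c3)c(F)c2)ccc1O` is one of three compounds, alongside compound 1 `CN(C)CCn1cnnc1-c1cc(Oc2ccc(NC(=O)N/N=C/c3ccc(O)c(Br)c3)cc2F)ccn1` and compound 2 `Cn1cnnc1-c1cc(Oc2ccc(NC(=O)N/N=C/c3ccccc3)cc2F)ccn1`, tested in a functional assay on MKN-45 cells (Homo sapiens) for cytotoxicity, read by MTT assay, with a stated time of 72 h; on this read-out higher numbers stand for weaker inhibition and lower numbers for stronger inhibition. In this assay compound 1 gives 1860 nM, compound 2 gives 7610 nM and compound 3 gives 3780 nM; compound 3 therefore stands second highest of the three, within the scatter of compound 2 but beyond it from compound 1. Compound 4 `CN(C)CCn1cnnc1-c1cc(Oc2ccc(NC(=O)N/N=C/c3ccccc3)cc2F)ccn1` differs from compound 3 by phenyl in place of 4-hydroxy-3-methoxyphenyl on a carbon with a double bond to nitrogen. Going by the values given here, the only measured step that swaps a group on an aromatic carbon, a 2.0-fold higher number from compound 1 to compound 3 (0.31 log units; beyond the scatter), is modest. Compound 2 carries the same phenyl group and shows a higher number than compound 3, so a rise is expected. The step from compound 3 to compound 4 is expected to be a 1.6-fold higher number from compound 3 to compound 4 (0.20 log units; within the scatter). Compound 4 is estimated at 6000 nM, between 2500 nM and 14000 nM.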

Compound 4, half-maximal inhibitory concentration: 2730 nM
Compound 4: the middle estimate sits 2.2-fold (0.34 log units) above what was measured, within the range that was stated.
By their numbers in this assay, from the lowest: compounds 1, 4, 3 and 2 (each within the scatter of the next, the first and the last beyond it).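

In this assay the substituents on the aromatic ring at the carbon with a double bond to nitrogen count for little here: a 1.4-fold lower number from compound 3 to compound 4 (0.14 log units; within the scatter) and a 1.5-fold higher number from compound 1 to compound 4 (0.17 log units; within the scatter) both stay within the scatter, so plain phenyl is not set apart from either substituted ring. The chain end shows a clearer step, with (dimethylamino)methyl in place of hydrogen giving a 2.8-fold lower number from compound 2 to compound 4 (0.45 log units; beyond the scatter) and lying beyond the scatter. Nothing available explains either result.

Open, from the compounds shown here alone, is whether an amine or a carboxylic acid on that phenyl ring would give a step beyond the scatter. Also open, going by these compounds, is whether a pyrrolidine or a longer chain would hold the step seen with (dimethylamino)methyl.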